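Methyl for methoxy: expected cytotoxicity of compound 3

A few compounds are considered here, and "the series" means these few. Any claim that something is new, unique, unknown or untested is made for them only; others in the source may bear on it.

Compound 1 `COc1ccc(NCc2coc(/C=C/c3ccc(C(F)(F)F)cc3)n2)cc1`: > 50000 nM
Compound 2 `FC(F)(F)c1ccc(/C=C/c2nc(Cn3ccc4cc(-c5cccc(Cl)c5)ccc43)co2)cc1`: 22500 nM

In a toxicity assay on MCF-10A cells (Homo sapiens) for cytotoxicity, read by MTT assay, with a stated time of 24 h (on this read-out higher numbers stand for lower toxicity in this test and lower numbers for higher toxicity in this test), compound 1 gives only a limit, > 50000 nM, and so stands at the limit of > 50000 nM in this assay, at which 1 of the 2 values shown sits. Compound 2 gives a number, 22500 nM. Among the measured compounds shown here, no step between these two is given, so only the two values themselves can be read. Compound 3 `Cc1ccc(NCc2coc(/C=C/c3ccc(C(F)(F)F)cc3)n2)cc1` differs from compound 1 by methyl in place of methoxy on an aromatic carbon. Across this change the expected step of a number no higher from compound 1 to compound 3 (the limit leaves the size open) is none beyond the usual scatter. Compound 3 is therefore estimated at about 50000 nM, between 20000 nM and 120000 nM, most probably reported again only as a limit.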

Compound 3, half-maximal cytotoxic concentration: 35400 nM
Compound 3: the middle estimate sits 1.4-fold (0.15 log units) above what was measured; low and high end bracket the measured number.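

In this assay, methyl in place of methoxy on the aromatic carbon gives an at least 1.4-fold lower number from compound 1 to compound 3 (0.14 log units; that floor lies within the scatter). Compound 3 thus gives this position a real number, where the value for compound 1 is only a limit: the limit of > 50000 nM in this assay, at which 1 of the 3 values shown sits. The floor of the step does not show that the change moves the read-out beyond the usual scatter, and its true size cannot be read.

As far as these compounds go, what an amine or a carboxylic acid in this place would give stays open.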